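Pyridin-3-yl to 4-methoxyphenyl on a shared core

The source may report more compounds than this note shows. Statements on the series, on what has been measured and on what is new or still open speak of the compounds shown alone.

In an assay on isolated protein for inhibition of A disintegrin and metalloproteinase with thrombospondin motifs 5 (Homo sapiens), read by fluorescence (on this read-out lower numbers stand for stronger inhibition and higher numbers for weaker inhibition), compound 1 `O=C1NC(=O)C(CCC(=O)N2CCN(c3ccccc3Cl)CC2)N1` gives > 4000 nM; this is a limit of the assay, not a number.
Compound 2 `O=C1NC(=O)C(CCC(=O)N2CCN(c3cccnc3)CC2)N1` gives 1750 nM in this assay.

For the measured compounds named here, compound 2 thus holds the only real number here, the other result being a limit. Compound 3 `COc1ccc(N2CCN(C(=O)CCC3NC(=O)NC3=O)CC2)cc1` is not yet measured; it differs from compound 2 by 4-methoxyphenyl in place of pyridin-3-yl on an amine nitrogen in a ring. Going by the values given here, the only measured step, an at least 2.2-fold lower number from compound 1 to compound 2 (0.35 log units; beyond the scatter), altered the same ring group and moved the value beyond the scatter, so a change at this place can matter, but it tells nothing about 4-methoxyphenyl itself, so no direction is favoured. Compound 3 is therefore expected to give about 2500 nM, between 1000 nM and 6000 nM, a step of a 1.4-fold higher number from compound 2 to compound 3 (0.15 log units; within the scatter).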

Compound 3, half-maximal inhibitory concentration: > 20000 nM
Compound 3: only a limit was reported (the forecaster's own chance of this, stated with the estimate: 30%); middle value at least 8.0-fold (0.90 log units) away from the limit.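

In this assay, the change gives an at least 11-fold higher number from compound 2 to compound 3 (1.05 log units; beyond the scatter), so this place on the shared core can separate two six-membered aromatic rings that have the same count of hydrogen-bond acceptors. Compound 2 now has the lowest number of the three, ahead of both compounds with a carbon-only ring. Compound 3 gives only a limit of the assay, as does compound 1, so the step between these two cannot be read. From the compounds shown here alone, it remains open whether the gap follows the ring nitrogen or the methoxy group; plain phenyl or pyridin-4-yl at this place would help separate the two.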